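Solubility notes on the series: compound 1 to compound 3

The source may report more compounds than this note shows. Statements on the series, on what has been measured and on what is new or still open speak of the compounds shown alone.

Compound 1 `COc1ccc2[nH]c(C(=O)N3CC(=O)N(Cc4ccccc4)[C@@H](CN4CCC(OC)CC4)C3)cc2c1` reaches a limit of a physicochemical assay for solubility, read by spectrophotometry, in phosphate buffer, with a stated time of 2 h, at pH 7.4 (on this read-out lower numbers stand for lower solubility and higher numbers for higher solubility), rather than a number: for compound 1 only > 25000 nM is known. Among the two values shown, compound 1 stands at the limit of > 25000 nM in this assay, at which 1 of the 2 values shown sits. Within the data shown here, compound 2 `COc1cccc(CN2C(=O)CN(C(=O)c3cc4cc(OC)ccc4[nH]3)C[C@@H]2c2ccccc2)c1` differs from compound 1 at several places at once and is no single step from it; in this assay compound 2 gives 13600 nM. Compound 3 `COc1ccc2[nH]c(C(=O)N3CC(=O)N(Cc4ccccc4)[C@@H](CN4CC5CCCCC5C4)C3)cc2c1` is not yet measured. It differs from compound 1 by a group of 9 heavy atoms (8 carbon, 1 nitrogen; one five-membered non-aromatic ring with 1 hetero atom, one six-membered non-aromatic ring of carbon only) in place of a group of 8 heavy atoms (6 carbon, 1 nitrogen, 1 oxygen; one six-membered non-aromatic ring with 1 hetero atom), on a saturated chain carbon bound to a saturated ring carbon. Among the measured compounds shown here, no measured pair in the set tells the size of such a change. Since the reading for compound 1 is only a limit, the expected step is toward lower solubility and of a size beyond the scatter: an at least 3.1-fold lower number from compound 1 to compound 3 (0.49 log units; beyond the scatter) is what is expected. Compound 3 is estimated at 8000 nM, with a range from 2000 nM to 25000 nM.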

Compound 3, solubility: 23800 nM
Estimate against measurement, compound 3: 3.0-fold (0.47 log units) below; measured number inside the range.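

The series now holds a change in one place, on a saturated chain carbon bound to a saturated ring carbon, and it reads as an at least 1.0-fold lower number from compound 1 to compound 3 (0.02 log units; that floor lies within the scatter). With the 4-methoxypiperidin-1-yl group replaced by the group holding one five-membered and one six-membered non-aromatic ring, compound 3 gives a true number in this assay, 23800 nM, so this position accepts the larger group with a reading still in the measurable range. The step as printed claims no drop beyond the scatter. Compound 1 remains a limit and not a number, so the real size of the step stays unfixed: the limit of > 25000 nM in this assay, at which 1 of the 3 values shown sits.

Going by these compounds, what a morpholin-4-yl or a dimethylamino group would give at this position stays open. Also open, on these data alone, is whether a carboxylic acid on the 4-position of the piperidine would move the reading in either direction.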